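The source may hold more compounds than are shown below. What is called first, only, known or untested is meant among the compounds shown, and "the series" means these compounds.

Measured so far in an in vitro functional assay on 1321-N1 cells for agonist activity at P2Y purinoceptor 6 (Homo sapiens); on this read-out higher numbers stand for an effect only at larger amounts of compound and lower numbers for an effect already at smaller amounts:
compound 1, `O=c1nc(SCc2ccccc2)ccn1[C@@H]1O[C@H](COP(=O)(O)OP(=O)(O)O)[C@@H](O)[C@H]1O`: 800 nM
compound 2, `O=C(O)CSc1ccn([C@@H]2O[C@H](COP(=O)(O)OP(=O)(O)O)[C@@H](O)[C@H]2O)c(=O)n1`: 1700 nM
compound 3, `CCSc1ccn([C@@H]2O[C@H](COP(=O)(O)OP(=O)(O)O)[C@@H](O)[C@H]2O)c(=O)n1`: 280 nM

Compound 1 holds the second highest of the three numbers: there is a 2.1-fold higher number from compound 1 to compound 2 (0.33 log units; beyond the scatter) and a 2.9-fold lower number from compound 1 to compound 3 (0.46 log units; beyond the scatter), while between the other two there is a 6.1-fold lower number from compound 2 to compound 3 (0.78 log units; beyond the scatter).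

Compound 4, `NC(=O)CSc1ccn([C@@H]2O[C@H](COP(=O)(O)OP(=O)(O)O)[C@@H](O)[C@H]2O)c(=O)n1`, is still to be measured. The change from compound 1 is carbamoyl in place of phenyl on a saturated chain carbon bound to a sulfur. The two measured exchanges of the same phenyl bear on it: toward carboxy the number rose modestly, toward methyl it fell modestly, both beyond the scatter. Carbamoyl, carrying one hydrogen-bond donor and one acceptor, is the closer match to carboxy, so a modest rise beyond the scatter is expected rather than the fall seen with methyl. Compound 4 is expected at 1300 nM, within 550 nM to 3000 nM. The expected step is therefore a 1.6-fold higher number from compound 1 to compound 4 (0.21 log units; within the scatter).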

Compound 4, half-maximal effective concentration: 18000 nM
Estimate against measurement, compound 4: 14-fold (1.14 log units) below; the measured number lies above the stated range.
By their numbers in this assay, from the lowest: compound 3; then compound 1; then compound 2; then compound 4.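

At this saturated chain carbon bound to a sulfur, carbamoyl gives the highest number in the series, with a 23-fold higher number from compound 1 to compound 4 (1.35 log units; beyond the scatter) and a 64-fold higher number from compound 3 to compound 4 (1.81 log units; beyond the scatter). The position also separates two closely matched groups, since amino in place of hydroxy on a carbonyl carbon gives an 11-fold higher number from compound 2 to compound 4 (1.02 log units; beyond the scatter), so compound 2 does not predict compound 4. Nothing available explains this step.

Open, from the compounds shown here alone, is whether a methyl ester or a dimethylamide at this carbonyl carbon gives a number nearer compound 2 or compound 4. Also open, going by these compounds, is whether a longer chain carrying the carbamoyl group changes the number.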